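This account rests on a few compounds, and the source may have more. Where it says the series, first, only, none or still open, it means among the compounds named here.

Measured so far in a functional assay on SW480 cells (Homo sapiens) for inhibition, read by MTT assay, with a stated time of 72 h; a higher number here means a weaker inhibitor of growth, a lower number a stronger inhibitor of growth:
compound 1 `COc1ccc(CNC(=O)/C(C#N)=C/c2ccc3ccccc3c2)cc1` — 41000 nM
compound 2 `COc1ccc(CNC(=O)/C(C#N)=C/c2cccc3ccccc23)cc1` — 14000 nM
compound 3 `N#C/C(=C\c1ccc2ccccc2c1)C(=O)NCc1ccc(Cl)c(Cl)c1` — 50000 nM

Compound 2 gives the lowest number of the three; its nearest neighbour is compound 1, and compound 3 lies furthest from it, both beyond the scatter, so compound 2 is the strongest growth inhibitor among the measured compounds. Compounds 1 and 2 share the same atoms joined differently; the difference between the two cores is not broken down here.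

The change from compound 1 to compound 3 is 3,4-dichlorophenyl in place of 4-methoxyphenyl on a saturated chain carbon bound to an amide-type nitrogen and produced a 1.2-fold higher number from compound 1 to compound 3 (0.09 log units; within the scatter). Compound 4 `N#C/C(=C\c1cccc2ccccc12)C(=O)NCc1ccc(Cl)c(Cl)c1` is not yet measured; it differs from compound 2 by 3,4-dichlorophenyl in place of 4-methoxyphenyl on a saturated chain carbon bound to an amide-type nitrogen, the same change made on the core of compound 2 instead of that of compound 1. Because the earlier step of a 1.2-fold higher number from compound 1 to compound 3 (0.09 log units; within the scatter) stayed within the scatter, the expected step from compound 2 to compound 4 is likewise small, a 1.2-fold higher number from compound 2 to compound 4 (0.08 log units; within the scatter). Compound 4 is therefore estimated at 17000 nM, with a range of 6000 nM to 45000 nM.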

Compound 4, concentration for 50% growth inhibition: 11000 nM
Compound 4: the middle estimate sits 1.5-fold (0.19 log units) above what was measured; low and high end bracket the measured number.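

Carried to the second core, the exchange of 4-methoxyphenyl for 3,4-dichlorophenyl in this assay gives a 1.3-fold lower number from compound 2 to compound 4 (0.10 log units; within the scatter), so the step is again small. Set side by side, the change behaves alike on both cores: the same change on two cores in this assay, a 1.2-fold higher number (0.09 log units; within the scatter) from compound 1 to compound 3 and a 1.3-fold lower number (0.10 log units; within the scatter) from compound 2 to compound 4, 1.6-fold (0.19 log units) apart, within the scatter of two such steps. This shows that, in these two pairs, the exchange leaves the number essentially unchanged whichever of the two cores carries it, but it gives no real direction for the change, and two cores cannot show that the same would hold on any other core.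

The compounds shown leave open how a quite different group on the saturated chain carbon bound to the amide-type nitrogen would fare, such as an unsubstituted phenyl, an amine or a carboxylic acid, and whether a longer chain in that place would shift the number. They also leave open what a replacement of the nitrile, which all four compounds carry, would do, for instance a carboxylic acid in its stead.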